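The source may hold more compounds than are shown below. What is called first, only, known or untested is meant among the compounds shown, and "the series" means these compounds.

Compound 1 `CC[C@H](C1CC1)n1c(=O)c(C)nc2c(-c3ccc(Cl)cc3Cl)ccnc21`: 8.2 nM
Compound 2 `CC[C@H](COC)n1c(=O)c(C)nc2c(-c3ccc(Cl)cc3Cl)nccc21`: 150 nM
Compound 3 `CC[C@H](C1CC1)n1c(=O)c(C)nc2c(-c3cc(C)c(OC)nc3C)ccnc21`: 15 nM

All three compounds were tested in a functional assay for antagonist activity at corticotropin-releasing factor receptor 1 (Rattus norvegicus); on this read-out lower numbers stand for stronger inhibition and higher numbers for weaker inhibition. Compound 1 gives 8.2 nM and compound 2 gives 150 nM. Compound 3, with 15 nM, stands second highest of the three numbers; its gap to compound 1 lies within the usual scatter, while compound 2 gives a clearly higher number, a gap beyond the scatter. No two of these compounds differ in a single place, so no single-step comparison is available among them.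

Compound 4 `CC[C@H](C1CC1)n1c(=O)c(C)nc2c(-c3ccc(OC)nc3C)ccnc21` has not yet been measured. It is derived from compound 3 by one change: hydrogen in place of methyl on an aromatic carbon. Nothing measured here tells how such a loss of a methyl on this ring affects the read-out, so any expectation rests on the change alone. A small step is expected from compound 3 to compound 4, toward a somewhat higher number, of about a 2.0-fold higher number from compound 3 to compound 4 (0.30 log units; within the scatter), though a result within the scatter would not be surprising. Compound 4 is thus estimated at 30 nM, with a range from 10 nM to 100 nM.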

Compound 4, half-maximal inhibitory concentration: 76 nM
Compound 4: the middle estimate sits 2.5-fold (0.40 log units) below what was measured; measured number inside the range.
By their numbers in this assay, from the lowest: compounds 1 and 3 (each within the scatter of the next); then compounds 4 and 2 (each within the scatter of the next).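

In this assay, going by these compounds alone, this is the first comparison that isolates the methyl ortho to the methoxy group on the six-membered aromatic ring with 1 nitrogen: its replacement by hydrogen gives a 5.1-fold higher number from compound 3 to compound 4 (0.70 log units; beyond the scatter) and so changes the read-out by more than the usual scatter. Placing 6-methoxy-2-methylpyridin-3-yl on the aromatic carbon that holds 2,4-dichlorophenyl in compound 1 gives a 9.3-fold higher number from compound 1 to compound 4 (0.97 log units; beyond the scatter) and shows that this hydrogen-bearing ring does not match the dichlorophenyl group. Nothing measured here explains what the methyl contributes.

Going by these compounds, whether an ethyl group, a chlorine atom or an amine on this carbon would keep the read-out near that of compound 3 remains open. Also open, on these data alone, is whether removing this methyl would have a similar effect with a different group on the ring nitrogen of the core.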